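Swapping an ethyl for 4-chlorophenyl on the core

This account rests on a few compounds, and the source may have more. Where it says the series, first, only, none or still open, it means among the compounds named here.

Measured so far:
Compound 1, `COc1ccc(CN2CC(=O)N(Cc3ccc(C(=O)NO)cc3)C2=O)cc1`: 28.2 nM
Compound 2, `CCCC1(c2ccccc2)NC(=O)N(Cc2ccc(C(=O)NO)cc2)C1=O`: 50.9 nM

Both compounds were tested in an assay on isolated protein for inhibition of protein deacetylase HDAC6 (Homo sapiens), read by fluorescence, with stated times of 10 min and 2 h; on this read-out higher numbers stand for weaker inhibition and lower numbers for stronger inhibition. Of the two numbers, that of compound 2 is the higher, yet its gap to compound 1 lies within the usual scatter, so the two cannot be told apart on this read-out.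

Compound 3, `O=C(NO)c1ccc(CN2C(=O)NC(Cc3ccc(Cl)cc3)(c3ccccc3)C2=O)cc1`, has not been measured. It differs from compound 2 in one place: 4-chlorophenyl in place of ethyl on a saturated chain carbon bound to a saturated ring carbon. Among the measured compounds shown here, no pair of measured compounds shows what such a change does in this setting, so the expectation rests only on the size of the group that enters and on the numbers of compounds 1 and 2.

The expected step is a 1.7-fold lower number from compound 2 to compound 3 (0.23 log units; within the scatter), which is modest, towards stronger inhibition and close to the scatter. Compound 3 is therefore estimated at 30 nM in this assay, within a range of 10 nM to 100 nM.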

Compound 3, half-maximal inhibitory concentration: 54 nM
Estimate against measurement, compound 3: 1.8-fold (0.26 log units) below; measured number inside the range.
By their numbers in this assay, from the lowest: compounds 1, 2 and 3 (each within the scatter of the next).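

Among the compounds shown here, the step of a 1.1-fold higher number from compound 2 to compound 3 (0.03 log units; within the scatter) in this assay is the first direct reading at this place, on a saturated chain carbon bound to a saturated ring carbon. Here, 4-chlorophenyl, with seven heavy atoms and an aromatic ring, stands in place of ethyl, with two heavy atoms and no ring, and the read-out cannot tell compound 2 and compound 3 apart. No supporting evidence here bears on why the much larger group leaves the number within the scatter.

On these data alone, it remains open whether this holds for other groups at this place, such as an amine, a carboxylic acid or a longer alkyl chain. The shown compounds also leave open what an unsubstituted phenyl would give in place of 4-chlorophenyl, and so whether the chlorine matters at all.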